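Methyl for Hydrogen: Free Fraction

The compounds below may be only part of what the source reports. "The series", "measured", "known", "first", "only" and "open" are said of these compounds alone.

Three compounds have been measured in an ADME assay on the whole organism (plasma, Macaca fascicularis) for protein binding, read by LC-MS, using equilibrium dialysis and cassette dosing, with a stated time of 24 h, at a dose of 1 mg/kg by the oral route; on this read-out higher numbers stand for a larger free fraction and lower numbers for a smaller free fraction:

Compound 1, `C[C@H](c1ccc(-c2cc(Cl)ccc2-c2nc(=O)o[nH]2)cc1)N(CC1CC1)c1nc2c(C(=O)O)cccc2o1`: 0.000108
Compound 2, `C[C@H](c1ccc(-c2ccccc2-c2nc(=O)o[nH]2)cc1)N(CC1CC1)c1nc2c(C(=O)O)cccc2o1`: 0.0000851
Compound 3, `CCCCN(c1nc2c(C(=O)NC)cccc2o1)[C@H](C)c1ccc(-c2ccccc2-c2nnn[nH]2)cc1`: 0.000975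

Compound 2 gives the lowest of the three numbers in this assay, though its nearest neighbour is compound 1, which sits within the scatter of it; compound 3 lies further away, beyond the scatter. Within the data shown here, the one single-point step among the measured compounds, hydrogen in place of chloro on an aromatic carbon, gave a 1.3-fold lower number from compound 1 to compound 2 (0.10 log units; within the scatter).

Compound 4, `Cc1ccc(-c2nc(=O)o[nH]2)c(-c2ccc([C@@H](C)N(CC3CC3)c3nc4c(C(=O)O)cccc4o3)cc2)c1`, has not yet been measured in this assay. It differs from compound 2 by methyl in place of hydrogen on an aromatic carbon. Among the measured compounds shown here, no measured step adds a methyl group, so the only comparison of similar scale is the chloro-to-hydrogen step from compound 1 to compound 2, which stayed within the scatter. On that basis a change of one small substituent on this ring is expected to move the free fraction little, if at all, and any shift beyond the scatter would be a surprise. For compound 4 the expected step is a 1.2-fold lower number from compound 2 to compound 4 (0.08 log units; within the scatter). Compound 4 is therefore estimated at 0.00007, with a range from 0.00003 to 0.00017.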

Compound 4, unbound fraction: 0.00023
The estimate for compound 4 lay 3.3-fold (0.52 log units) below the measured number, outside the stated range (above it).
By their numbers in this assay, from the lowest: compounds 2 and 1 (each within the scatter of the next); then compound 4; then compound 3.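

Among these compounds, at this aromatic carbon, meta to a large group and para to a group of 6 heavy atoms, the earlier compounds had offered only a swap that stayed within the scatter, whereas in this assay methyl in place of hydrogen gives a 2.7-fold higher number from compound 2 to compound 4 (0.43 log units; beyond the scatter), so the read-out at this position does respond to a change of one heavy atom, if modestly. Methyl also separates from chloro on the same carbon, with a 2.1-fold higher number from compound 1 to compound 4 (0.33 log units; beyond the scatter), even though chloro and hydrogen themselves could not be told apart, so among the three substituents seen here methyl alone stands apart from the other two. The material at hand holds nothing that accounts for this difference.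

Going by these compounds, it remains open whether the rise continues, stops or reverses with other groups on this carbon, such as ethyl, methoxy, trifluoromethyl or an amine, since a single methyl compound sets no trend. On these data alone, it is equally open whether methyl in place of hydrogen would give a similar step on the core of compound 3, with its butyl chain and methyl amide.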